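The compounds below may be only part of what the source reports. "The series", "measured", "known", "first", "only" and "open" are said of these compounds alone.

In an ADME assay on Vero cells (Chlorocebus sabaeus) for cytotoxicity, read by MTT assay, with a stated time of 72 h (a higher number here means that more compound is tolerated, a lower number that less compound is tolerated), compound 1 `COc1ccc(/C=C(\C)C(=O)/C=C/c2ccc(/C=C/C(=O)/C(C)=C/c3ccc(OC)cc3)cc2)cc1` gives 460000 nM, compound 2 `COc1ccc(/C=C(\C)C(=O)/C=C/c2ccc(Br)cc2)cc1` gives 31200 nM, and compound 3 `CC/C(=C\c1ccc(Cl)cc1)C(=O)/C=C/c1ccccc1Br` gives 24400 nM. Compound 2 holds the second highest of these three numbers: compound 3 lies nearest, within the scatter of it, while compound 1 lies well above it, beyond the scatter. Compound 4 `COc1ccc(/C=C(\C)C(=O)/C=C/c2ccccc2Cl)cc1` has not yet been measured in this assay. It differs from compound 2 in one place: 2-chlorophenyl in place of 4-bromophenyl on a double-bonded chain carbon bound to a double-bonded chain carbon. Among the compounds with values here, no measured pair shows this change on its own, so the expectation rests on the closeness of compound 2 and compound 3. The step expected here is a 1.2-fold lower number from compound 2 to compound 4 (0.06 log units; within the scatter), none beyond the scatter. Compound 4 is therefore estimated at 27000 nM, with a range from 12000 nM to 60000 nM.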

Compound 4, half-maximal cytotoxic concentration: 74300 nM
For compound 4 the middle estimate is 2.8-fold (0.44 log units) below the measured one; the measured number lies above the stated range.
By their numbers in this assay, from the lowest: compounds 3 and 2 (each within the scatter of the next); then compound 4; then compound 1.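

In this assay, 2-chlorophenyl in place of 4-bromophenyl on a double-bonded chain carbon bound to a double-bonded chain carbon gives a 2.4-fold higher number from compound 2 to compound 4 (0.38 log units; beyond the scatter), the only single change shown at this position. The swap alone therefore moves the number beyond the scatter, though the step is modest. Nothing available accounts for this step. The halogen and its place on the phenyl ring change together, and the compounds shown do not separate the two. From the compounds shown here alone, how an amine or a carboxylic acid on that ring would read also remains open.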